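A few compounds are considered here, and "the series" means these few. Any claim that something is new, unique, unknown or untested is made for them only; others in the source may bear on it.

Of the compounds shown here, three have so far been measured in a functional assay on SK-OV-3 cells (Homo sapiens) for inhibition, read by sulforhodamine B assay, with a stated time of 48 h; a higher number here means a weaker inhibitor of growth, a lower number a stronger inhibitor of growth. Compound 1 `COc1ccc(-c2cc(/C=C/C(=O)c3ccc(N)cc3)[nH]n2)cc1` gives 4720 nM, compound 2 `COc1ccc(-c2cc(/C=C/C(=O)c3ccc(N)cc3)[nH]n2)cc1OC` gives 4860 nM, and compound 3 `COc1cc(C(=O)/C=C/c2cc(-c3cc(OC)c(OC)c(OC)c3)n[nH]2)cc(OC)c1OC` gives 3200 nM. Compound 2 and compound 1 differ in a single place: hydrogen in place of methoxy on an aromatic carbon. That change produced a 1.0-fold lower number from compound 2 to compound 1 (0.01 log units; within the scatter). Compound 3 differs from compound 2 in more than one place, and the difference between the two cores is not broken down here; their two values lie within the scatter of each other.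

Compound 4 `COc1ccc(-c2cc(/C=C/C(=O)c3cc(OC)c(OC)c(OC)c3)[nH]n2)cc1OC` has not yet been measured. It differs from compound 3 in one place: hydrogen in place of methoxy on an aromatic carbon. This is the same kind of change as that from compound 2 to compound 1, but not the same: in compound 3 the carbon that loses the methoxy is also meta to a methoxy group, which is not so in compound 2. Because the earlier step was measured as a 1.0-fold lower number from compound 2 to compound 1 (0.01 log units; within the scatter), a similarly small step is expected here, namely a 1.1-fold higher number from compound 3 to compound 4 (0.03 log units; within the scatter). For compound 4 the estimate in this assay is 3400 nM, with a likely range from 1500 nM to 7500 nM.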

Compound 4, concentration for 50% growth inhibition: 5470 nM
Compound 4: middle estimate off by 1.6-fold (0.21 log units), on the low side; the measured number falls inside the stated range.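

In this assay, replacing a methoxy with hydrogen on an aromatic carbon gave a 1.7-fold higher number from compound 3 to compound 4 (0.23 log units; within the scatter). Set beside the same replacement on the other core, this step does not stand apart from the earlier one: the same change on two cores in this assay, a 1.0-fold lower number (0.01 log units; within the scatter) from compound 2 to compound 1 and a 1.7-fold higher number (0.23 log units; within the scatter) from compound 3 to compound 4, 1.8-fold (0.25 log units) apart, within the scatter of two such steps

So the two cores give no sign that this change behaves differently from one to the other, and on both it stays small enough to be lost in the ordinary spread of repeat measurements; this does not show that the change is equally harmless throughout the series, since two pairs are few and a real but small difference between the cores would go unseen.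

Still open, from the compounds shown here alone, is whether a different group in place of that methoxy, such as a hydroxyl or a longer ethoxy chain, would give a step beyond the scatter. Also open, going by these compounds, is how the numbers would respond to a change elsewhere in the molecule, for example at the carbonyl or the carbon-carbon double bond that all four compounds share.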